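This account rests on a few compounds, and the source may have more. Where it says the series, first, only, none or still open, it means among the compounds named here.

Going by the values given here, compound 2 `N#CC1=C(N)N(c2ccc(S(N)(=O)=O)cc2)C2=C(CCCC2)C1c1ccc(O)cc1` is one of two compounds measured in a functional assay on Ehrlich cells (Mus musculus) for cytotoxicity, read by trypan blue exclusion, with a stated time of 2 h, tested at 50 ug/mL; a lower number here means a weaker effect, a higher number a stronger effect of the compound at the concentration tested. In this assay, among the compounds with values here, compound 2 gives 60%; the only other compound, compound 1 `N#CC1=C(N)N(c2ccc(S(N)(=O)=O)cc2)C2=C(CCCC2)C1c1ccccc1O`, gives 50%, and the step of a number 10 percentage points higher from compound 1 to compound 2 (within the scatter) lies within the scatter, so the two cannot be told apart on these numbers. Compound 3 `COc1ccccc1C1C(C#N)=C(N)N(c2ccc(S(N)(=O)=O)cc2)C2=C1CCCC2` has not yet been measured. Its change from compound 2 is 2-methoxyphenyl in place of 4-hydroxyphenyl on a saturated ring carbon. Within the data shown here, only one measured step bears on this, and only in part: a number 10 percentage points higher from compound 1 to compound 2 (within the scatter) shows that exchanging the two hydroxyphenyl groups on the same saturated ring carbon changed nothing beyond the scatter. Among the measured compounds shown here, no measured pair contains a 2-methoxyphenyl group, so that part of the change is untested. For this assay, the expected step of a number 8 percentage points lower from compound 2 to compound 3 (within the scatter) is therefore none beyond the scatter. Compound 3 is estimated at 52%, with a range from 35% to 70%.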

Compound 3, a percentage reported as activity, at one concentration (the size of the read-out at that concentration, not a potency): 50%
Estimate against measurement, compound 3: 2 percentage points above; the range from low to high includes it.
By their numbers in this assay, from the lowest: compounds 1, 3 and 2 (each within the scatter of the next).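

In this assay, putting methyl in place of hydrogen on the oxygen of the 2-hydroxyphenyl group gives no change at the digits printed from compound 1 to compound 3 (within the scatter), and the change from the 4-hydroxyphenyl group gives a number 10 percentage points lower from compound 2 to compound 3 (within the scatter). The hydroxyl hydrogen on this aromatic ring can therefore be capped with methyl without any change that these numbers can resolve, and all three compounds remain indistinguishable at this single concentration. No measurement shown here explains why they read alike.

Every group shown on this saturated ring carbon is a phenyl ring bearing a hydroxyl or methoxy group, so it remains open whether an unsubstituted phenyl, a phenyl with an amine or a carboxylic acid, or a longer alkoxy chain would read differently. A read-out at one concentration also leaves the compounds' potencies unknown.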